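Acetylating a Hydroxyl on a Weakly Cytotoxic Ester Scaffold

This account rests on a few compounds, and the source may have more. Where it says the series, first, only, none or still open, it means among the compounds named here.

Three esters of the same aromatic acid have been tested in a functional assay on RS4-11 cells (Homo sapiens) for cytotoxicity, read by MTT assay, with a stated time of 72 h; on this read-out lower numbers stand for stronger inhibition and higher numbers for weaker inhibition. Compound 1 `COc1ccc(C(=O)OCC2=CC[C@@]3(C)CCC(C(C)C)=C3CC2)cc1` gives 44100 nM, compound 2 `COc1ccc(C(=O)O[C@H]2CC(C)=C[C@H](O)[C@@]3(C)[C@@H](OC(C)=O)C[C@@](O)(C(C)C)[C@H]23)cc1` gives 34400 nM, and compound 3 `COc1ccc(C(=O)OCC2=CC[C@@]3(C)CC[C@]4(C(C)C)O[C@]34CC2)cc1` gives 60900 nM. Compound 2 holds the lowest of the three numbers, yet its gap to compound 1 and its gap to compound 3 both fall within the usual scatter of repeated measurements, so the three cannot be ranked on these data.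

Compound 4 `COc1ccc(C(=O)O[C@H]2CC(C)=C[C@H](OC(C)=O)[C@@]3(C)[C@@H](OC(C)=O)C[C@@](O)(C(C)C)[C@H]23)cc1` has not yet been measured. It differs from compound 2 in one place: acetyl in place of hydrogen on an oxygen on a saturated carbon. Within the data shown here, no pair of measured compounds shows what such an exchange does in this assay, so the expectation rests only on the values of compound 2 and its neighbours, all of which sit close together at weak inhibition. Compound 4 is therefore expected to stay in the same region, with a step of a 1.0-fold higher number from compound 2 to compound 4 (0.02 log units; within the scatter) that need not exceed the scatter. The estimated value for compound 4 is 36000 nM, with a range from 15000 nM to 85000 nM.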

Compound 4, half-maximal inhibitory concentration: 2800 nM
Estimate against measurement, compound 4: 13-fold (1.11 log units) above; measured number below the stated range.
By their numbers in this assay, from the lowest: compound 4; then compounds 2, 1 and 3 (each within the scatter of the next).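

In this assay, among these compounds, placing acetyl on this oxygen in place of hydrogen, which turns a hydroxy into an acetoxy, gives a 12-fold lower number from compound 2 to compound 4 (1.09 log units; beyond the scatter) and so brings the first large step. This shows that the oxygen on the saturated carbon is not a neutral spot on the scaffold: one small change there is enough to move the read-out well beyond the scatter. Nothing measured here explains how the acetyl group produces this step.

The compounds shown leave open whether the step belongs to acetyl itself or would also follow from other groups on the same oxygen, such as a methyl ether, a propionyl ester or a benzoyl ester. On these data alone, the step also rests on a single pair, so the effect of acetyl on the other hydroxyl of compound 4 remains unknown.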